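The source may hold more compounds than are shown below. What is called first, only, known or untested is meant among the compounds shown, and "the series" means these compounds.

Measured so far:
- Compound 1 `CC(C)(C)[C@@H](O)C(=O)N1C[C@@H]2C[C@@H]2[C@H]1C(=O)NCc1cc(Cl)ccc1-n1cnnn1`: 97000 nM
- Compound 2 `O=C(NCc1cc(Cl)ccc1-n1cnnn1)[C@@H]1C[C@H]2C[C@H]2N1C(=O)[C@H](O)c1ccccc1`: 100000 nM
- Compound 3 `CCCC[C@@H](O)C(=O)N1N=CC[C@H]1C(=O)NCc1cc(Cl)ccc1-n1cnnn1`: 59000 nM

In a physicochemical assay for solubility, measured as kinetic solubility, at pH 6.8 (a higher number here means a more soluble compound, a lower number a less soluble compound), compound 2 gives 100000 nM. Although this is the highest of the three numbers, it cannot be ranked above the others, since compound 1 at 97000 nM and compound 3 at 59000 nM both lie within the usual scatter of repeated measurements.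

Compound 4 `O=C(NCc1cc(Cl)ccc1-n1cnnn1)[C@@H]1C[C@@H]2C[C@@H]2N1C(=O)[C@H](O)c1ccccc1` has not yet been measured. Its relation to compound 2 is unusually simple: the two compounds have the same atoms and bonds and differ only in configuration as drawn: 2 of 4 stereo elements differ; a stereocentre at a saturated ring carbon is drawn R in compound 2 and S in compound 4; a stereocentre at a saturated ring carbon is drawn R in compound 2 and S in compound 4. Nothing leaves and nothing enters, so the two compounds have the same atoms and bonds. R and S are the labels for the two possible spatial arrangements at a stereocentre, and here the arrangement differs at two saturated ring carbons.

Among the measured compounds shown here, no two measured compounds differ in one place only, so the data give no direct measure of what such a change does. Still, compound 3 at 59000 nM differs from compound 2 in far more than configuration and stays within the scatter of it. A change beyond the scatter is therefore not expected. The estimated step of a 1.1-fold lower number from compound 2 to compound 4 (0.05 log units; within the scatter) is small. For compound 4 the expected value is 90000 nM, with an estimated range from 50000 nM to 140000 nM.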

Compound 4, solubility: 97000 nM
For compound 4 the middle estimate is 1.1-fold (0.03 log units) below the measured one; low and high end bracket the measured number.
By their numbers in this assay, from the lowest: compounds 3, 1, 4 and 2 (each within the scatter of the next).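

The pair gives the first direct reading of a single kind of change in this set, and it can be read that way because nothing else separates the two structures: the fact that compounds 2 and 4 differ only in the configuration as drawn

In this assay, reversing the drawn arrangement at the two saturated ring carbons gives a 1.0-fold lower number from compound 2 to compound 4 (0.01 log units; within the scatter). Among the compounds shown here, at these two ring carbons, then, this pair offers a measured case in which the change of configuration cannot be told apart from repeat scatter, where the earlier compounds could only hint at this through comparisons that differed in many places.

As far as these compounds go, both ring carbons switch together in this pair, so what each one does alone stays open, and two separate shifts that offset each other cannot be ruled out. From the compounds shown here alone, it also stays open whether the same holds when the phenyl group on the hydroxyl-bearing side chain is replaced by something quite different, such as an amine or a carboxylic acid, since this one pair speaks only for the groups it carries.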